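The compounds below may be only part of what the source reports. "The series", "measured", "known", "first", "only" and "open" are said of these compounds alone.

Measured in a physicochemical assay for lipophilicity; on this read-out higher numbers stand for higher lipophilicity and lower numbers for lower lipophilicity:
- compound 1 `Cc1nc(C)c(C(=O)NCC(=O)Oc2ccc(-c3cc(=O)c4c(O)c(O)c(O)cc4o3)cc2)nc1C`: 2.8
- compound 2 `Cc1nc(C)c(C(=O)N[C@H](CC(C)C)C(=O)Oc2ccc(-c3cc(=O)c4c(O)c(O)c(O)cc4o3)cc2)nc1C`: 0.91
- compound 3 `Cc1nc(C)c(COC(=O)NCC(=O)Oc2ccc(-c3cc(=O)c4c(O)c(O)c(O)cc4o3)cc2)nc1C`: 2.1

Compound 3 stands second highest of the three, under compound 1 and over compound 2. The next structure is compound 4 `CC[C@H](C)[C@@H](NC(=O)OCc1nc(C)c(C)nc1C)C(=O)Oc1ccc(-c2cc(=O)c3c(O)c(O)c(O)cc3o2)cc1`, with sec-butyl in place of hydrogen on a saturated chain carbon bound to an amide-type nitrogen and a carbonyl carbon. The closest measured step, isobutyl in place of hydrogen at that same place, is large: a number 1.89 log units lower from compound 1 to compound 2 (beyond the scatter). The other measured step, modest, is a number 0.70 log units lower from compound 1 to compound 3 (beyond the scatter), and it shows the carbonyl-side change already present in compound 3. That isobutyl step is a single case, so a large drop in this assay is expected, though somewhat smaller. The expected step is a number 1.50 log units lower from compound 3 to compound 4 (beyond the scatter). The estimate for compound 4 is 0.6, with an expected range of -0.2 to 1.6.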

Compound 4, partition coefficient: 2.83
Estimate against measurement, compound 4: 2.23 log units below; the whole stated range lies below it.
By their numbers in this assay, from the lowest: compound 2; then compound 3; then compounds 1 and 4 (each within the scatter of the next).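

In this assay, sec-butyl in place of hydrogen on the saturated chain carbon gives a number 0.73 log units higher from compound 3 to compound 4 (beyond the scatter) and so runs opposite to the isobutyl step, a number 1.89 log units lower from compound 1 to compound 2 (beyond the scatter) at the same place. A branched four-carbon group at this place therefore has no single direction across these two pairs, and the direction cannot be carried from one pair to the other. Nothing at hand accounts for the reversal.

Going by these compounds, the two pairs differ in both the entering group and the carbonyl-side group, so it remains open which of these goes with the change in direction. Also open, on these data alone, is how a carboxylic acid or an amine at this place would read.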